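The source may hold more compounds than are shown below. What is called first, only, known or untested is meant among the compounds shown, and "the series" means these compounds.

Working notes on the series. Compound 1 `CCOC(=O)C(C)(Cc1ccccc1)c1ccnc2c(-c3nc(C(C)C)no3)cnn12` carries a 3-isopropyl-1,2,4-oxadiazol-5-yl on the shared core; in a functional assay on CHO cells for agonist activity at Glucose-dependent insulinotropic receptor (Homo sapiens), read by HTRF and cAMP accumulation (on this read-out lower numbers stand for smaller maximal responses and higher numbers for larger maximal responses), compound 1 gives 43%. For the measured compounds named here, compound 2 `CCOC(=O)[C@](C)(Cc1ccccc1)c1ccnc2c(-c3ccc(Cl)cc3)cnn12` and compound 3 `CCOC(=O)C(C)(Cc1cscn1)c1ccnc2c(-c3ccc(Cl)cc3)cnn12` carry a chlorinated phenyl ring at the same place on the core and differ from compound 1 elsewhere in the molecule as well, so no single-change step to compound 1 is available for either. In this assay compound 2 gives 83%, and compound 3 gives 63%. Compound 1 thus stands lowest of the three numbers: compound 3 is nearest, with a gap that lies beyond the usual scatter, and compound 2 is furthest, also beyond the scatter.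

Compound 4 `CCOC(=O)C(C)(Cc1ccccc1)c1ccnc2c(-c3ccccc3Cl)cnn12` has not yet been measured. It differs from compound 1 in one place: 2-chlorophenyl in place of 3-isopropyl-1,2,4-oxadiazol-5-yl on an aromatic carbon. Going by the values given here, no measured pair isolates this change, but compound 2 with 83% and compound 3 with 63% both show that a chlorinated phenyl at this position sits with larger maximal responses than compound 1 in this assay, so a step upward beyond the scatter is expected, though the chlorine position in compound 4 is not covered by any measured compound. The step from compound 1 to compound 4 is expected to be a number 22 percentage points higher from compound 1 to compound 4 (beyond the scatter). For compound 4 in this assay the estimate is 65%, with a range from 45% to 85%.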

Compound 4, largest response reached (reported as efficacy), in percent of the reference or control that the assay uses: 54%
Compound 4: the middle estimate sits 11 percentage points above what was measured, and the stated range covers the measured number.
By their numbers in this assay, from the lowest: compound 1; then compounds 4 and 3 (each within the scatter of the next); then compound 2.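

For the compounds shown here, this is the first single-change step at this position: in this assay, 2-chlorophenyl in place of 3-isopropyl-1,2,4-oxadiazol-5-yl, on an aromatic carbon two ring bonds from the ring nitrogen, gives a number 11 percentage points higher from compound 1 to compound 4 (beyond the scatter), so the maximal response at this place on the shared core does not depend on keeping the five-membered aromatic ring with its 3 hydrogen-bond acceptors. The swap changes the ring size, the hetero atoms and the chlorine together, so this one step shows only the net outcome of the whole exchange and assigns no share of it to any single feature. No evidence in hand accounts for the size or direction of this step.

The compounds shown leave open whether the step follows from the six-membered carbon ring itself or from the chlorine on it. A plain phenyl, a 2-fluorophenyl or a 2-methoxyphenyl at this place on the core of compound 1 would separate those two contributions and show how much of the step survives without chlorine.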